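The compounds below may be only part of what the source reports. "The series", "measured", "known", "first", "only" and "open" are said of these compounds alone.

Measured in a toxicity assay on HaCaT cells (Homo sapiens) for cytotoxicity, read by MTT assay; a higher number here means a weaker inhibitor, a lower number a stronger inhibitor:
compound 1 `Cc1ccc(-n2nc(-c3ccc(C(F)(F)F)cc3O)nc2-c2ccccc2O)cc1`: 81800 nM
compound 2 `CC(C)c1ccc(-n2nc(-c3ccc(C(F)(F)F)cc3O)nc2-c2ccccc2O)cc1`: 51400 nM
compound 3 `Cc1cc(C)cc(-n2nc(-c3ccc(C(F)(F)F)cc3O)nc2-c2ccccc2O)c1`: 127000 nM

Compound 3 is clearly separated only from compound 2. The data show a 1.6-fold higher number from compound 1 to compound 3 (0.19 log units; within the scatter), and also a 2.5-fold higher number from compound 2 to compound 3 (0.39 log units; beyond the scatter).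

Compound 4 `Oc1cc(C(F)(F)F)ccc1-c1nc(-c2ccccc2O)n(-c2cc(F)cc(F)c2)n1` carries 3,5-difluorophenyl in place of 3,5-dimethylphenyl on an aromatic nitrogen. For the measured compounds named here, no measured step tests fluorine, so the evidence is indirect. The closest guide is how little the values moved when this same group changed, and a 1.6-fold lower number from compound 1 to compound 2 (0.20 log units; within the scatter) is equally small. No step beyond the scatter is therefore expected in this assay, and the direction is uncertain. The estimate means a 1.3-fold lower number from compound 3 to compound 4 (0.10 log units; within the scatter). Compound 4 is expected at 100000 nM, with an estimated range from 45000 nM to 210000 nM.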

Compound 4, half-maximal inhibitory concentration: 45400 nM
Estimate against measurement, compound 4: 2.2-fold (0.34 log units) above; the measured number falls inside the stated range.
By their numbers in this assay, from the lowest: compounds 4, 2, 1 and 3 (each within the scatter of the next, the first and the last beyond it).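

In this assay, replacing 3,5-dimethylphenyl with 3,5-difluorophenyl on the aromatic nitrogen, exchanging only methyl for fluorine, gives a step beyond the scatter (a 2.8-fold lower number from compound 3 to compound 4 (0.45 log units; beyond the scatter)). For the compounds shown here, the earlier steps all changed where the groups sat on this ring, so this is the first sign that the substituent itself can move the number. Compound 4 stays within the scatter of the two para-free comparisons only in name of value (a 1.1-fold lower number from compound 2 to compound 4 (0.05 log units; within the scatter); a 1.8-fold lower number from compound 1 to compound 4 (0.26 log units; within the scatter)), so it stands apart from compound 3 alone. From the compounds shown here alone, how a ring carrying an amine or a carboxylic acid at this position would behave remains open. No measurement here bears on what lies behind this difference.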